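A few compounds are considered here, and "the series" means these few. Any claim that something is new, unique, unknown or untested is made for them only; others in the source may bear on it.

Measured compounds: compound 2 `Cc1nnc(/C(=N\O)c2nc3ccccc3s2)s1` gives 38000 nM; compound 3 `O/N=C(\c1ccccc1)c1nc2ccccc2s1` gives > 100000 nM; compound 1 `Cc1nc(/C(=N\O)c2nc3ccccc3s2)no1` gives "not determined" (no result reported).

Compound 1 carries no number in an ADME assay on CHO cells (Cricetulus griseus) for cytotoxicity (a lower number here means a stronger inhibitor, a higher number a weaker inhibitor), so it stands unplaced among the values shown. Compound 3 sits at a limit of this assay, (the limit of > 100000 nM in this assay, at which 1 of the 3 values shown sits). Among the compounds with values here, the one measured step, an at least 2.6-fold higher number from compound 2 to compound 3 (0.42 log units; beyond the scatter), swaps a heteroaromatic ring for a carbocycle and weakens. The change to compound 4 `O/N=C(/c1nc2ccccc2s1)C1CCCCC1` is cyclohexyl in place of 5-methyl-1,2,4-oxadiazol-3-yl on a carbon with a double bond to nitrogen; it likewise trades an aromatic heterocycle for an all-carbon ring, so a weakening of comparable size is expected in this assay, though compound 1 gives no starting number to anchor it. Compound 4 is therefore estimated at 90000 nM, between 30000 nM and 300000 nM.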

Compound 4, half-maximal inhibitory concentration: 51600 nM
The estimate for compound 4 lay 1.7-fold (0.24 log units) above the measured number; measured number inside the range.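

Compound 3 remains a limit of this assay, not a number: the limit of > 100000 nM in this assay, at which 1 of the 4 values shown sits. With cyclohexyl in place of phenyl, the result is an at least 1.9-fold lower number from compound 3 to compound 4 (0.28 log units; that floor lies within the scatter), so this change shows no firm separation. With cyclohexyl in place of 5-methyl-1,3,4-thiadiazol-2-yl, the result is a 1.4-fold higher number from compound 2 to compound 4 (0.13 log units; within the scatter), so compound 4 goes against the weakening seen with phenyl, and an all-carbon ring at this place does not by itself shift the number beyond the scatter. The compounds shown leave open whether an amine or a longer alkyl chain in place of cyclohexyl would move the number in this assay.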